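The source may report more compounds than this note shows. Statements on the series, on what has been measured and on what is new or still open speak of the compounds shown alone.

Among the measured compounds shown here, in a functional assay on NCI/ADR-RES cells (Homo sapiens) for inhibition (a higher number here means a weaker inhibitor of growth, a lower number a stronger inhibitor of growth), compound 1 `O=S(=O)(/C=C/c1ccc(Cl)cc1Cl)Cc1ccc(Nc2ncnc3ccccc23)cc1` reads 5000 nM and compound 2 `O=S(=O)(/C=C/c1ccc(C(F)(F)F)cc1F)Cc1ccc(Nc2ncnc3ccccc23)cc1` reads 100000 nM on the numbers so far. Compound 3 `O=S(=O)(/C=C/c1ccc(Cl)cc1Cl)Cc1ccc(Nc2ncnc3ccc(Br)cc23)cc1` has only a limit in this assay and that limit is > 100000 nM with no exact number behind it. Compound 4 `O=S(=O)(/C=C/c1ccc(C(F)(F)F)cc1F)Cc1ccc(Nc2ncnc3ccc(Br)cc23)cc1` carries 2-fluoro-4-(trifluoromethyl)phenyl in place of 2,4-dichlorophenyl on a double-bonded chain carbon bound to a double-bonded chain carbon. The same exchange without the bromo is the large step of a 20-fold higher number from compound 1 to compound 2 (1.30 log units; beyond the scatter) and the bromo in place of hydrogen is the large step of an at least 20-fold higher number from compound 1 to compound 3 (1.30 log units; beyond the scatter) in the same direction. The step expected in this assay is a number no higher from compound 3 to compound 4 (the limit leaves the size open) and no fall in the number is expected. For compound 4 the estimate is 100000 nM with an expected range of 40000 nM to 200000 nM and a report as a limit is likely.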

Compound 4, concentration for 50% growth inhibition: 85000 nM
Compound 4: middle estimate off by 1.2-fold (0.07 log units), on the high side, within the range that was stated.
By their numbers in this assay, from the lowest: compound 1; then compounds 4 and 2 (each within the scatter of the next).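

In this assay, with bromo on the core, 2-fluoro-4-(trifluoromethyl)phenyl in place of 2,4-dichlorophenyl gives an at least 1.1-fold lower number from compound 3 to compound 4 (0.07 log units; that floor lies within the scatter), so the outcome of this exchange depends on the core: the same change on two cores in this assay, a 20-fold higher number (1.30 log units; beyond the scatter) from compound 1 to compound 2 and an at least 1.1-fold lower number (0.07 log units; that floor lies within the scatter) from compound 3 to compound 4, at least 23-fold (1.37 log units) apart, beyond the scatter of two such steps Bromo in place of hydrogen on an aromatic carbon likewise depends on the other group, giving a 1.2-fold lower number from compound 2 to compound 4 (0.07 log units; within the scatter), so the two changes do not add: the same change on two cores in this assay, an at least 20-fold higher number (1.30 log units; beyond the scatter) from compound 1 to compound 3 and a 1.2-fold lower number (0.07 log units; within the scatter) from compound 2 to compound 4, at least 23-fold (1.37 log units) apart, beyond the scatter of two such steps The value of compound 3 is a limit, so both gaps are floors: the limit of > 100000 nM in this assay, at which 1 of the 4 values shown sits.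

From the compounds shown here alone, whether an amine or a methoxy group in place of bromo on that aromatic carbon would give a number near that of compound 1 stays open.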